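Adding a chlorophenyl to the methoxy of compound 1

This account rests on a few compounds, and the source may have more. Where it says the series, first, only, none or still open, it means among the compounds named here.

Compound 1, `COc1ccc(C(O)C2OC(=O)c3c(OC)cc(OC)cc32)cc1`, in a functional assay on RAW264.7 cells (Mus musculus) for inhibition, read by Griess assay, with stated times of 1 h and 24 h (a lower number here means a stronger inhibitor, a higher number a weaker inhibitor), gives > 10000 nM, which is a limit of the assay and not a number.
Compound 2, `COCCOc1ccc(C(O)C2OC(=O)c3c(OC)cc(OC)cc32)cc1`, in this assay gives > 10000 nM, again a limit.
Compound 3, `COc1cc(OC)c2c(c1)C(C(O)c1ccc(OCCOc3ccccc3)cc1)OC2=O`, in this assay gives > 10000 nM, also a limit.

Compound 1 therefore stands only at a limit, and the two other values shown are limits as well (the limit of > 10000 nM in this assay, at which 3 of the 3 values shown sit). The steps a step that the two limits leave unreadable from compound 1 to compound 2 and a step that the two limits leave unreadable from compound 1 to compound 3 and the step that the two limits leave unreadable from compound 2 to compound 3 are all left unreadable by these limits, so no size can be read from any of them.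

The unmeasured compound 4, `COc1cc(OC)c2c(c1)C(C(O)c1ccc(OCc3ccc(Cl)cc3)cc1)OC2=O`, differs from compound 1 by 4-chlorophenyl in place of hydrogen on a saturated chain carbon bound to an oxygen on an aromatic ring. The related changes made so far, methoxymethyl and phenoxymethyl entering at the same place, gave no readable step, so the present change offers no measured basis for a direction. The most that the numbers support is that compound 4 is expected to sit near the limit, with the step that the limit leaves unreadable from compound 1 to compound 4 estimated as not readable. Compound 4 is estimated at 15000 nM, within 3000 nM to 50000 nM.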

Compound 4, half-maximal inhibitory concentration: 4320 nM
Compound 4: the middle estimate sits 3.5-fold (0.54 log units) above what was measured, and the stated range covers the measured number.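

In this assay, this place on a saturated chain carbon bound to an oxygen on an aromatic ring gives its first readable change: 4-chlorophenyl in place of hydrogen produces an at least 2.3-fold lower number from compound 1 to compound 4 (0.36 log units; beyond the scatter). The same group also reads against the two earlier groups at this place, methoxymethyl and phenoxymethyl, with an at least 2.3-fold lower number from compound 2 to compound 4 (0.36 log units; beyond the scatter) and an at least 2.3-fold lower number from compound 3 to compound 4 (0.36 log units; beyond the scatter), while the steps among those three earlier compounds cannot be read. An aromatic ring in the entering group does not alone give a measurable number, as phenoxymethyl in compound 3 shows, and the full size of all three new steps stays unknown: the limit of > 10000 nM in this assay, at which 3 of the 4 values shown sit.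

On these data alone, whether the chlorine is needed remains open, as a plain phenyl or a 4-fluorophenyl at this place could read the same or differently. As far as these compounds go, how an amine or a carboxylic acid on that ring would read also remains open.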